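Sulfonyl substituent variation: working notes toward compound 4

The source may hold more compounds than are shown below. What is called first, only, known or untested is meant among the compounds shown, and "the series" means these compounds.

Measured compounds:
compound 1 `CNS(=O)(=O)Cc1noc2ccccc12` — 23 mg/kg
compound 2 `CN(C)S(=O)(=O)Cc1noc2ccccc12` — 37 mg/kg
compound 3 `CNS(=O)(=O)Cc1noc2ccc(F)cc12` — 35 mg/kg

In a functional assay on the whole organism (strain STD-dd) with Mus musculus as the target, in the maximal electroshock model, with a stated time of 2 h (on this read-out higher numbers stand for an effect only at larger amounts of compound and lower numbers for an effect already at smaller amounts), compound 1 gives 23 mg/kg. Compound 2 gives 37 mg/kg, and compound 3 gives 35 mg/kg. Compound 3 sits between the other two numbers; its nearest neighbour is compound 2 and its furthest compound 1, and all three numbers lie within the scatter of one another, so no ordering among them can be read.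

Compound 4 `CN1CCN(S(=O)(=O)Cc2noc3ccc(F)cc23)CC1` differs from compound 3 by 4-methylpiperazin-1-yl in place of methylamino on a sulfonyl sulfur. Going by the values given here, the one measured step that touches the same part of the molecule is a 1.6-fold higher number from compound 1 to compound 2 (0.21 log units; within the scatter), a change within the scatter. That step replaces a single hydrogen, whereas the entering group here brings a six-membered ring and loses the hydrogen-bond donor, so the earlier step is only a loose guide; the fluoro step a 1.5-fold higher number from compound 1 to compound 3 (0.18 log units; within the scatter) does not bear on the sulfonyl position at all. A small rise in the number is therefore expected, not clearly beyond the scatter; the expected step is a 1.4-fold higher number from compound 3 to compound 4 (0.15 log units; within the scatter).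

Compound 4 is estimated at 50 mg/kg in this assay, with a range from 25 mg/kg to 100 mg/kg.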

Compound 4, dose for half-maximal effect: 100 mg/kg
Compound 4: middle estimate off by 2.0-fold (0.30 log units), on the low side, and the stated range covers the measured number.
By their numbers in this assay, from the lowest: compounds 1, 3 and 2 (each within the scatter of the next); then compound 4.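

In this assay, going by these compounds alone, the substituent on the sulfonyl sulfur can move the number: 4-methylpiperazin-1-yl in place of methylamino gives a 2.9-fold higher number from compound 3 to compound 4 (0.46 log units; beyond the scatter), the only step so far that lies beyond the scatter. The earlier change touching this part of the molecule, methyl in place of hydrogen on a sulfonamide nitrogen, gave a 1.6-fold higher number from compound 1 to compound 2 (0.21 log units; within the scatter), so that smaller change did not show this sensitivity. Nothing available accounts for the step in compound 4.

The change brings in a larger group and a six-membered ring and removes the hydrogen-bond donor all at once, and the compounds shown do not separate these features. From the compounds shown here alone, a piperidin-1-yl or morpholin-4-yl group on the sulfonyl sulfur remains open, as does the effect of 4-methylpiperazin-1-yl on the core of compound 1, without the fluoro group.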